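The source may report more compounds than this note shows. Statements on the series, on what has been measured and on what is new or still open speak of the compounds shown alone.

Compound 2 `O=C(/C=C/c1ccccc1OC(F)(F)F)c1ccccc1` gives > 10000 nM in a functional assay on RAW264.7 cells (Mus musculus) for inhibition, read by fluorescence, with stated times of 1 h, 24 h and 30 min (a higher number here means a weaker inhibitor, a lower number a stronger inhibitor), and this value is a limit of the assay, not a number. Compound 1 `O=C(/C=C/c1ccccc1F)c1cccc(O)c1` bears a 3-hydroxyphenyl group and gives > 10000 nM in this assay and this too is a limit. The record so far is the limit of > 10000 nM in this assay, at which 2 of the 2 values shown sit, and it holds no measured number to build on.

The change from compound 2 to compound 3 `O=C(/C=C/c1ccccc1OC(F)(F)F)c1cccc(O)c1` is hydroxy in place of hydrogen on an aromatic carbon and it reads as hydroxy in place of hydrogen on an aromatic carbon, meta to a large group. Among the measured compounds shown here, no measured step shows what this change does in this assay. A small step is expected, and if one appears at all, the expected direction is toward a stronger inhibitor. A reading that stays at the limit is about as likely. Compound 1 has the 3-hydroxyphenyl group present, and its reading of > 10000 nM is a limit. The estimated size is a number no higher from compound 2 to compound 3 (the limit leaves the size open) and it is only a rough expectation. Compound 3 is estimated at 10000 nM in this assay with an expected range from 3000 nM to 20000 nM as the likely span.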

Compound 3, half-maximal inhibitory concentration: 1610 nM
Compound 3: the middle estimate sits 6.2-fold (0.79 log units) above what was measured; the whole stated range lies above it.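

In this assay, among the compounds shown here, hydroxy in place of hydrogen on an aromatic carbon, meta to a large group, gives the first measured number, with an at least 6.2-fold lower number from compound 2 to compound 3 (0.79 log units; beyond the scatter) on the phenyl to 3-hydroxyphenyl change. The 3-hydroxyphenyl group alone does not bring the reading off the limit, as trifluoromethoxy in place of fluoro on the same background gives an at least 6.2-fold lower number from compound 1 to compound 3 (0.79 log units; beyond the scatter) in the same assay. In these three compounds, a measured number therefore appears only where the hydroxy and the trifluoromethoxy group stand together, and both steps start from a limit of the assay, which leaves their full size open: the limit of > 10000 nM in this assay, at which 2 of the 3 values shown sit.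

The compounds shown leave open whether the hydroxy group itself is needed at this place or whether a methoxy group, an amine or a carboxylic acid in its place would also give a measured number. They also leave open whether the trifluoromethoxy group is needed as such, or whether a chloro or a methoxy group in its place would serve alongside the hydroxy.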